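Swapping a chlorobenzyl cap for cyclopropylmethyl

The source may hold more compounds than are shown below. What is called first, only, known or untested is meant among the compounds shown, and "the series" means these compounds.

Compound 3 `O=C(CCCCCCn1cc(Nc2ncc3ccn(Cc4cccc(Cl)c4)c3n2)cn1)NO` gives the highest number of the three measured hydroxamic acids in an assay on isolated protein for inhibition of protein deacetylase HDAC6 (Homo sapiens), with a stated time of 60 min (a lower number here means a stronger inhibitor, a higher number a weaker inhibitor), at 36.8 nM. Compound 2 `O=C(CCCCCCn1cc(Nc2ncc3ccn(Cc4cccc(F)c4)c3n2)cn1)NO` stands nearest with 14.7 nM, and compound 1 `CS(=O)(=O)c1ccc(-n2ccc3cnc(Nc4cnn(CCCCCCC(=O)NO)c4)nc32)cc1` furthest with 5.9 nM. The steps of a 2.5-fold higher number from compound 2 to compound 3 (0.40 log units; beyond the scatter), a 6.2-fold higher number from compound 1 to compound 3 (0.79 log units; beyond the scatter) and a 2.5-fold higher number from compound 1 to compound 2 (0.40 log units; beyond the scatter) are all beyond the scatter, yet all modest. Compound 4 `O=C(CCCCCCn1cc(Nc2ncc3ccn(CC4CC4)c3n2)cn1)NO` carries cyclopropyl in place of 3-chlorophenyl on a saturated chain carbon bound to an aromatic nitrogen; read one bond further out, 3-chlorobenzyl becomes cyclopropylmethyl. Among the measured compounds shown here, no measured step replaces an aromatic cap with a non-aromatic one, so the bearing of the measured steps is indirect: they show that changing the group on that aromatic nitrogen shifted this assay only modestly, as in a 6.2-fold higher number from compound 1 to compound 3 (0.79 log units; beyond the scatter), and that the smaller halogen gave the lower number, as in a 2.5-fold higher number from compound 2 to compound 3 (0.40 log units; beyond the scatter). The hydroxamic acid chain and the shared core are untouched. The expected step, a 1.2-fold lower number from compound 3 to compound 4 (0.09 log units; within the scatter), is therefore small, with no firm direction beyond the scatter. Compound 4 is estimated at 30 nM, with a range from 10 nM to 100 nM.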

Compound 4, half-maximal inhibitory concentration: 16 nM
The estimate for compound 4 lay 1.9-fold (0.27 log units) above the measured number, and the stated range covers the measured number.
By their numbers in this assay, from the lowest: compound 1; then compounds 2 and 4 (each within the scatter of the next); then compound 3.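

In this assay, the 3-chlorophenyl on this saturated chain carbon can give way to a cyclopropyl with no loss, as a 2.3-fold lower number from compound 3 to compound 4 (0.36 log units; beyond the scatter) shows, so an aromatic ring at this place is not required for a number in this range. The cyclopropylmethyl group also matches the 3-fluorobenzyl group, with a 1.1-fold higher number from compound 2 to compound 4 (0.04 log units; within the scatter), while the 4-(methylsulfonyl)phenyl directly on the aromatic nitrogen keeps the lowest number, as a 2.7-fold higher number from compound 1 to compound 4 (0.43 log units; beyond the scatter) makes clear. Nothing at hand explains why these groups rank as they do.

The compounds shown leave open whether a larger saturated ring such as cyclohexylmethyl would follow cyclopropylmethyl here. They also leave open whether a group carrying an amine or a carboxylic acid on this nitrogen would hold the number in this assay.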